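Two Ribosides Measured, a Third Awaiting Its Number

The source may report more compounds than this note shows. Statements on the series, on what has been measured and on what is new or still open speak of the compounds shown alone.

Of the compounds shown here, two so far have a number in an assay on isolated protein for binding affinity to Equilibrative nucleoside transporter 1 (Homo sapiens); a lower number here means a stronger inhibitor, a higher number a weaker inhibitor. Compound 1 `Nc1nc(SCc2ccc(F)cc2)c2ncn([C@@H]3O[C@H](CO)[C@@H](O)[C@H]3O)c2n1` gives 1150 nM in this assay. Compound 2 `Cc1c(CNc2ncnc3c2ncn3[C@@H]2O[C@H](CO)[C@@H](O)[C@H]2O)cccc1[N+](=O)[O-]` gives 427 nM in this assay, the lower of the two numbers; its gap to compound 1 lies beyond the usual scatter, so compound 2 stands as the stronger inhibitor of the measured pair.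

Compound 3 `COc1cccc(CNc2ncnc3c2ncn3[C@@H]2O[C@H](CO)[C@@H](O)[C@H]2O)c1` has not been measured. It differs from compound 2 in a single place: 3-methoxyphenyl in place of 2-methyl-3-nitrophenyl on a saturated chain carbon bound to a nitrogen on an aromatic ring. Among the measured compounds shown here, no measured pair shows this exchange, so nothing in the data tells how it acts on the number. The step is therefore expected to be modest, at most a little beyond the scatter, and more likely toward a higher number than a lower one; the estimated step of a 1.5-fold higher number from compound 2 to compound 3 (0.18 log units; within the scatter) reflects this. Compound 3 is expected to give about 650 nM in this assay, within a range from 200 nM to 2200 nM.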

Compound 3, half-maximal inhibitory concentration: 115000 nM
For compound 3 the middle estimate is 180-fold (2.25 log units) below the measured one; the whole stated range lies below it.
By their numbers in this assay, from the lowest: compound 2; then compound 1; then compound 3.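

Among the compounds shown here, the exchange of 2-methyl-3-nitrophenyl for 3-methoxyphenyl on a saturated chain carbon bound to a nitrogen on an aromatic ring is the only single-place change read so far in this assay, and it gives a 270-fold higher number from compound 2 to compound 3 (2.43 log units; beyond the scatter), a large step beyond the scatter. It shows that the number is highly sensitive to what the phenyl ring at this place carries, even with the rest of the structure unchanged. Nothing at hand accounts for the size of this step.

Because the exchange removes the methyl and the nitro and adds the methoxy all at once, the compounds shown cannot assign the step to any one of these groups. They also leave open how a phenyl ring carrying only the nitro, or an amine or a carboxylic acid in its place, would read in this assay.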